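The source may report more compounds than this note shows. Statements on the series, on what has been measured and on what is new or still open speak of the compounds shown alone.

Measured compounds:
compound 1, `Oc1ccccc1/C=N/c1nnc(SCc2nnc(-c3ccccc3)o2)s1`, 7100 nM in a functional assay on SMMC-7721 cells (Homo sapiens) for inhibition, read by CCK-8 assay; a higher number here means a weaker inhibitor, a lower number a stronger inhibitor
compound 2, `Oc1ccccc1/C=N/c1nnc(SCc2nnc(-c3ccccc3Cl)o2)s1`, 31800 nM in this assay
compound 3, `Oc1ccccc1/C=N/c1nnc(SCc2nnc(-c3ccccc3Br)o2)s1`, 6780 nM in this assay

Compound 1 gives the second highest of the three numbers in this assay; its nearest neighbour is compound 3, and the two sit within the scatter of each other, while compound 2 stands apart. The measured steps are a 4.5-fold higher number from compound 1 to compound 2 (0.65 log units; beyond the scatter) and a 1.0-fold lower number from compound 1 to compound 3 (0.02 log units; within the scatter), both halogen for hydrogen on the phenyl ring, and between them a 4.7-fold lower number from compound 2 to compound 3 (0.67 log units; beyond the scatter). They show that replacing a hydrogen on this ring can leave the number where it is or raise it modestly, and nothing more.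

Compound 4, `O=[N+]([O-])c1ccc(-c2nnc(CSc3nnc(/N=C/c4ccccc4O)s3)o2)cc1`, is not yet measured. It differs from compound 1 by nitro in place of hydrogen on an aromatic carbon. Within the data shown here, no measured step places a nitro anywhere, and none alters the carbon that the nitro group enters here, so the halogen steps bear on compound 4 only loosely. The step from compound 1 to compound 4 is therefore expected to be small and uncertain in direction, leaning toward a somewhat higher number, as a 1.4-fold higher number from compound 1 to compound 4 (0.15 log units; within the scatter). Compound 4 is estimated at 10000 nM in this assay, within 3000 nM to 35000 nM.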

Compound 4, half-maximal inhibitory concentration: 16900 nM
For compound 4 the middle estimate is 1.7-fold (0.23 log units) below the measured one; the measured number falls inside the stated range.
By their numbers in this assay, from the lowest: compounds 3 and 1 (each within the scatter of the next); then compounds 4 and 2 (each within the scatter of the next).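

Phenyl to 4-nitrophenyl gives a 2.4-fold higher number from compound 1 to compound 4 (0.38 log units; beyond the scatter), which shows that a group para to a large group can move the number in this assay beyond the scatter, and that a rise on this ring is not confined to the 2-chlorophenyl of compound 2. Against the 2-bromophenyl, the change gives a 2.5-fold higher number from compound 3 to compound 4 (0.40 log units; beyond the scatter), while against the 2-chlorophenyl it gives a 1.9-fold lower number from compound 2 to compound 4 (0.27 log units; within the scatter), so compound 4 falls with compound 2, and compound 3, which stays level with compound 1, goes against any rule that a substituent here raises the number. Nothing available bears on the reason for this result.

The compounds shown do not separate the nitro group from its place, as no other group stands at this carbon and no nitro group stands elsewhere on the ring. Going by these compounds, how an amine or a carboxylic acid at this carbon would read also remains open.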